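Aryl hydrazone variation on the triazolylpyridine ether series

The compounds below may be only part of what the source reports. "The series", "measured", "known", "first", "only" and "open" are said of these compounds alone.

Measured compounds:
compound 1 `CN(C)CCn1cnnc1-c1cc(Oc2ccc(NC(=O)N/N=C/c3c(Cl)cccc3Cl)cc2F)ccn1`, 350 nM
compound 2 `CN(C)CCn1cnnc1-c1cc(Oc2ccc(NC(=O)N/N=C/c3cc(Br)c(O)c(Br)c3)cc2F)ccn1`, 3760 nM

In a functional assay on NCI-H460 cells (Homo sapiens) for cytotoxicity, read by MTT assay, with a stated time of 72 h (on this read-out higher numbers stand for weaker inhibition and lower numbers for stronger inhibition), compound 2 gives 3760 nM, the highest of the two numbers; its nearest neighbour is compound 1, reached by an 11-fold higher number from compound 1 to compound 2 (1.03 log units; beyond the scatter). Compound 3 `CN(C)CCn1cnnc1-c1cc(Oc2ccc(NC(=O)N/N=C/c3ccc(F)cc3Cl)cc2F)ccn1` carries 2-chloro-4-fluorophenyl in place of 3,5-dibromo-4-hydroxyphenyl on a carbon with a double bond to nitrogen. Among the compounds with values here, the only step that bears on this is the one from compound 1 to compound 2, which was large and in the direction of weaker inhibition: exchanging a 2,6-dichlorophenyl for the 3,5-dibromo-4-hydroxyphenyl. Compound 3 reverses that exchange in kind, returning to a halogenated phenyl with no hydroxyl, so a large step back toward the number of compound 1 is expected. The step from compound 2 to compound 3 is therefore estimated as an 8.4-fold lower number from compound 2 to compound 3 (0.92 log units; beyond the scatter). Compound 3 is expected to give 450 nM, in the range 150 nM to 1500 nM.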

Compound 3, half-maximal inhibitory concentration: 720 nM
For compound 3 the middle estimate is 1.6-fold (0.20 log units) below the measured one, within the range that was stated.
By their numbers in this assay, from the lowest: compound 1; then compound 3; then compound 2.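

In this assay, the group on the carbon with a double bond to nitrogen can be a halogenated phenyl other than 2,6-dichlorophenyl and keep most of the lower number: 2-chloro-4-fluorophenyl gives a 5.2-fold lower number from compound 2 to compound 3 (0.72 log units; beyond the scatter), yet remains apart from 2,6-dichlorophenyl, with a 2.1-fold higher number from compound 1 to compound 3 (0.31 log units; beyond the scatter). Both compounds without the hydroxyl, compound 1 and compound 3, therefore give lower numbers than compound 2, although the change to compound 3 alters the hydroxyl and the halogens together, and the data do not divide the step among them. No measurement at hand explains these differences.

As far as these compounds go, it remains open how much of the step follows the hydroxyl and how much the two bromines. A methoxy group or an amine in place of that hydroxyl, with both bromines kept, would separate these contributions.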